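The source may report more compounds than this note shows. Statements on the series, on what has been measured and on what is new or still open speak of the compounds shown alone.

Measured compounds:
Compound 1 `OC(CCn1nc2c(Br)c(Br)c(Br)c(Br)c2n1)c1cccc(Cl)c1` — 107%
Compound 2 `CC(O)CCn1nc2c(Br)c(Br)c(Br)c(Br)c2n1` — 79%

Both were read in a functional assay on MCF7 cells (Homo sapiens) for antiproliferative activity, read by MTT assay, with a stated time of 48 h, tested at 12.5 uM; on this read-out lower numbers stand for a stronger effect and higher numbers for a weaker effect at the one concentration tested. Compound 2 stands lowest of the two numbers; its nearest neighbour is compound 1, which differs from it only at one place, and that step, a number 28 percentage points lower from compound 1 to compound 2 (beyond the scatter), lies beyond the scatter. Compound 3 `OC(CCn1nc2c(Br)c(Br)c(Br)c(Br)c2n1)c1ccc(Cl)cc1` has not yet been measured. Its structural change from compound 2 is 4-chlorophenyl in place of methyl on a saturated chain carbon bound to an oxygen on a saturated carbon and a saturated chain carbon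

Within the data shown here, the only step that bears on this change is the one from compound 1 to compound 2, where methyl replaced 3-chlorophenyl on the same saturated chain carbon and the number fell by a modest amount. Compound 3 brings a chlorophenyl back onto that carbon, so the step is expected to run the other way and to be of about the same size, a number 26 percentage points higher from compound 2 to compound 3 (beyond the scatter). Compound 3 is therefore estimated at 105%, with a range from 85% to 125%.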

Compound 3, a percentage reported as activity, at one concentration (the size of the read-out at that concentration, not a potency): 100%
Beside the measured number, compound 3's estimate is 5 percentage points above it, within the range that was stated.
By their numbers in this assay, from the lowest: compound 2; then compounds 3 and 1 (each within the scatter of the next).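

In this assay the 4-chlorophenyl group on this saturated chain carbon reads much like the 3-chlorophenyl group, with a number 7 percentage points lower from compound 1 to compound 3 (within the scatter) and so no difference that can be told apart between these two chlorophenyl groups. Putting 4-chlorophenyl in place of methyl gives a number 21 percentage points higher from compound 2 to compound 3 (beyond the scatter) and this shows that the separation of compound 2 from compound 1 is not tied to the 3-chlorophenyl group alone, since compound 2 stands apart from both chlorophenyl compounds. Nothing available explains why methyl and the chlorophenyl groups differ at this place.

The compounds shown leave open what a phenyl group without chlorine would give here. They also leave open whether an amine or a longer chain on this carbon would give a lower number than methyl does in compound 2.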